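Swapping the benzyl thioether of compound 1 for a cyclopropylmethyl

The source may report more compounds than this note shows. Statements on the series, on what has been measured and on what is new or still open speak of the compounds shown alone.

Measured compounds:
- compound 1 `Cc1cc(Nc2cc(-c3ccccc3)[nH]n2)n2nc(SCc3ccc(Br)cc3)nc2n1`: 4760 nM
- compound 2 `Cc1cc(Nc2cc(C(C)(C)C)[nH]n2)n2nc(SCc3ccc(Br)cc3)nc2n1`: 12400 nM
- compound 3 `Cc1cc(Nc2ccn(Cc3ccc(F)cc3)n2)n2nc(SCc3ccc(Br)cc3)nc2n1`: 19400 nM

In a functional assay on PC-9 cells (Homo sapiens) for inhibition, read by MTT assay, with a stated time of 72 h (a lower number here means a stronger inhibitor, a higher number a weaker inhibitor), compound 1 gives 4760 nM, the lowest of the three numbers. Its nearest neighbour is compound 2, reached by a 2.6-fold higher number from compound 1 to compound 2 (0.42 log units; beyond the scatter); compound 3, at 19400 nM, lies further off. Compound 4 `Cc1cc(Nc2cc(-c3ccccc3)[nH]n2)n2nc(SCC3CC3)nc2n1` is not yet measured. It differs from compound 1 in one place: cyclopropyl in place of 4-bromophenyl on a saturated chain carbon bound to a sulfur. For the measured compounds named here, no measured step touches this part of the shared core; the only step available, from compound 1 to compound 2, changes the other end of the molecule, so it offers no guide to the present change. With nothing to anchor the direction, compound 4 is expected to stay close to compound 1, and the step of a 1.5-fold higher number from compound 1 to compound 4 (0.17 log units; within the scatter) is estimated to fall near or only a little beyond the scatter, with a wide range to reflect that uncertainty. Compound 4 is therefore estimated at 7000 nM, between 2500 nM and 20000 nM.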

Compound 4, half-maximal inhibitory concentration: > 50000 nM
Compound 4 was reported as a limit (the forecaster's own chance of this, stated with the estimate: 10%); at least 7.1-fold (0.85 log units) between middle value and limit.
By their numbers in this assay, from the lowest: compound 1; then compounds 2 and 3 (each within the scatter of the next). At a limit, above all of these: compound 4.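

Replacing (4-bromobenzyl)sulfanyl with (cyclopropylmethyl)sulfanyl gives an at least 10-fold higher number from compound 1 to compound 4 (1.02 log units; beyond the scatter) in this assay. Compound 4 gives > 50000 nM, which is a limit of the assay and not a number: the limit of > 50000 nM in this assay, at which 1 of the 4 values shown sits. Compound 1, compound 2 and compound 3 all carry the 4-bromobenzyl group, so only this result shows that the group cannot be exchanged for cyclopropylmethyl on the core of compound 1 without activity leaving the measured range.

This single change removes the bromine and the six-membered aromatic ring together, so the compounds shown cannot tell which of the two matters, or whether the number of heavy atoms does. An unsubstituted benzyl, a 4-chlorobenzyl or a longer chain such as n-butyl at this place would begin to separate these possibilities.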